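This account rests on a few compounds, and the source may have more. Where it says the series, first, only, none or still open, it means among the compounds named here.

Among the measured compounds shown here, in a functional assay on cells (Homo sapiens) for antiproliferative activity, read by MTT assay, with a stated time of 48 h (a lower number here means a stronger inhibitor, a higher number a weaker inhibitor), compound 1 `CCN(CC)CCn1c(N)c(-c2nc3ccccc3[nH]2)c2nc(C#N)c(C#N)nc21` gives 25400 nM and stands highest of the two numbers measured so far. Compound 2 `N#Cc1nc2c(-c3nc4ccccc4[nH]3)c(N)n(CCCN3CCCCC3)c2nc1C#N` comes in lower at 6230 nM on the same scale. The change to compound 3 `CCN(CC)CCn1c(N)c(-c2nc3ccccc3n2C)c2nc(C#N)c(C#N)nc21` is methyl in place of hydrogen on an aromatic nitrogen in the core of compound 1, that is, methyl in place of hydrogen on an aromatic nitrogen, while the chain stays as it is. For the measured compounds named here, the one measured step is a 4.1-fold lower number from compound 1 to compound 2 (0.61 log units; beyond the scatter) and it is modest, but it concerns the chain and not this nitrogen, so it bears only indirectly. Going by the values given here, no measured pair tests this methyl, so no step beyond the scatter is expected in this assay in either direction. The estimated step is a 1.1-fold higher number from compound 1 to compound 3 (0.04 log units; within the scatter) with wide uncertainty. For compound 3 the expected value is 28000 nM with an estimated range from 9000 nM to 80000 nM as the likely span.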

Compound 3, half-maximal inhibitory concentration: > 50000 nM
Compound 3: a limit, no number; the forecaster's own chance of this, stated with the estimate: 20%; middle value at least 1.7-fold (0.25 log units) away from the limit.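

In this assay compound 3 gives > 50000 nM, which is a limit of the assay and not a number. Methyl in place of hydrogen on this aromatic nitrogen, a place the earlier chain change did not touch, brings an at least 1.9-fold higher number from compound 1 to compound 3 (0.29 log units; that floor lies within the scatter), so the result points to no gain from this methyl, but it does not establish a step beyond the scatter and leaves the true size unread. Compound 3 is the only compound shown that stands at such a limit: the limit of > 50000 nM in this assay, at which 1 of the 3 values shown sits.

The compounds shown leave open whether an ethyl or a benzyl group on this nitrogen would read the same way as methyl. They also leave open what the methyl does when the chain is the piperidin-1-yl chain of compound 2.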